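The compounds below may be only part of what the source reports. "The series", "measured", "known", "first", "only" and "open" are said of these compounds alone.

For the measured compounds named here, in an ADME assay on L6 cells (Rattus norvegicus) for inhibition, read by resazurin assay, with a stated time of 72 h (on this read-out lower numbers stand for stronger inhibition and higher numbers for weaker inhibition), compound 2 `CC(=O)O[C@@H]1[C@H](OC(C)=O)[C@@H](CN=[N+]=[N-])O[C@H]1n1cnc2c(N)nc(Cl)nc21` gives 141000 nM; the only other number measured, that of compound 1 `CC(=O)O[C@@H]1[C@H](OC(C)=O)[C@@H](C[S+](C)[O-])O[C@H]1n1cnc2c(N)nc(Cl)nc21` at 168000 nM, sits within the scatter of it, so the two cannot be told apart. Compound 3 `CC(=O)O[C@@H]1[C@H](OC(C)=O)[C@@H](CN2C(=O)c3ccccc3C2=O)O[C@H]1n1cnc2c(N)nc(Cl)nc21` differs from compound 2 by a group of 11 heavy atoms (8 carbon, 1 nitrogen, 2 oxygen; one five-membered non-aromatic ring with 1 hetero atom, one six-membered aromatic ring of carbon only) in place of a group of 3 heavy atoms (3 nitrogen; no ring), on a saturated chain carbon bound to a saturated ring carbon. Going by the values given here, the one measured step at that same saturated chain carbon, a 1.2-fold lower number from compound 1 to compound 2 (0.08 log units; within the scatter), did not leave the scatter, so the step of a 1.0-fold lower number from compound 2 to compound 3 (0.00 log units; within the scatter) for compound 3 is expected to stay within the scatter as well. The estimate for compound 3 in this assay is 140000 nM, with a range from 50000 nM to 400000 nM.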

Compound 3, half-maximal inhibitory concentration: 144000 nM
Estimate against measurement, compound 3: 1.0-fold (0.01 log units) below, and the stated range covers the measured number.
By their numbers in this assay, from the lowest: compounds 2, 3 and 1 (each within the scatter of the next).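

In this assay, a group of 11 heavy atoms carrying two rings can replace the azido group on this saturated chain carbon, giving a 1.0-fold higher number from compound 2 to compound 3 (0.01 log units; within the scatter). Replacing the sulfur-bearing group of compound 1 with the same two-ring group gives a 1.2-fold lower number from compound 1 to compound 3 (0.07 log units; within the scatter), so in these compounds going from 3 to 11 heavy atoms at this place leaves the number within the scatter. No measurement shown here explains this result. Open, as far as these compounds go, is whether an amine or a carboxylic acid on this carbon would move the number beyond the scatter.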